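A Methylsulfonyl Group Added to Compound 2

The compounds below may be only part of what the source reports. "The series", "measured", "known", "first", "only" and "open" are said of these compounds alone.

In a physicochemical assay for metabolic stability, read by HPLC, in phosphate buffer, with a stated time of 24 h, at 37 degrees C, at pH 7.4, tested at 1 uM, in the presence of a further agent that is not named here (on this read-out lower numbers stand for a shorter-lived compound and higher numbers for a longer-lived compound), compound 2 `C[C@H]1[C@H](NC(=O)OCCCCC2CCCCC2)C(=O)N1Oc1ccccc1` gives > 24 h, which is a limit and not a number. Compound 1 `C[C@H]1[C@H](NC(=O)OCCCCC2CCCCC2)C(=O)N1OCCCS(C)(=O)=O` gives > 24 h, also a limit. Among the compounds with values here, the only measured step nearby is a step that the two limits leave unreadable from compound 1 to compound 2, so it offers no size to carry forward. Compound 3 `C[C@H]1[C@H](NC(=O)OCCCCC2CCCCC2)C(=O)N1Oc1ccc(S(C)(=O)=O)cc1` has methylsulfonyl in place of hydrogen on an aromatic carbon of compound 2: methylsulfonyl in place of hydrogen on an aromatic carbon. The expected step is an at least 1.3-fold lower number from compound 2 to compound 3 (0.12 log units; that floor lies within the scatter), a modest downward guess with no measured size behind it. For compound 3 the estimated half-life is 18 h, with an expected range from 5 h to 60 h.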

Compound 3, half-life: 12.1 h
The estimate for compound 3 lay 1.5-fold (0.17 log units) above the measured number; the range from low to high includes it.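

Within the data shown here, compound 3 is the first compound here whose half-life in this assay reads as a number and not as a limit. Methylsulfonyl in place of hydrogen on the aromatic carbon gives an at least 1.9-fold lower number from compound 2 to compound 3 (0.29 log units; that floor lies within the scatter), and 4-(methylsulfonyl)phenyl in place of 3-(methylsulfonyl)propyl on the oxygen gives an at least 1.9-fold lower number from compound 1 to compound 3 (0.29 log units; that floor lies within the scatter). Both steps are only floors, so the true sizes may be larger, because of one shared limit: the limit of > 24 h in this assay, at which 2 of the 3 values shown sit.

The step between compound 1 and compound 2 cannot be read. As far as these compounds go, whether an amine or a carboxylic acid on that same aromatic carbon would also give a readable half-life stays open.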